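Sulfonyl aryl exchange in the imidazole-piperidine amide series

This account rests on a few compounds, and the source may have more. Where it says the series, first, only, none or still open, it means among the compounds named here.

Among the compounds with values here, compound 2 `O=C(c1ccc(Cl)c(C(F)(F)F)c1)N1CCC(n2cncc2-c2ccc(OS(=O)(=O)c3cccc(Br)c3)cc2)CC1` gives 896 nM in an assay on HEK293 cells for antagonist activity at P2X purinoceptor 7 (Homo sapiens), read by fluorescence, with a stated time of 2 h (on this read-out higher numbers stand for weaker inhibition and lower numbers for stronger inhibition), the one numerical value in the set. Compound 1 `CC(=O)Oc1ccc(-c2cncn2C2CCN(C(=O)c3ccc(Cl)c(C(F)(F)F)c3)CC2)cc1` reports a limit in this assay, namely > 10000 nM. The step of an at least 11-fold lower number from compound 1 to compound 2 (1.04 log units; beyond the scatter) is the sole measured one and concerns the group on the phenol oxygen, not the aryl on the sulfonyl sulfur, so it bears only loosely on compound 3 `O=C(c1ccc(Cl)c(C(F)(F)F)c1)N1CCC(n2cncc2-c2ccc(OS(=O)(=O)c3cccc4cnccc34)cc2)CC1`, where (isoquinolin-5-yl in place of 3-bromophenyl on a sulfonyl sulfur). Within the data shown here, no measured step covers this exchange; the expected step of a 1.3-fold lower number from compound 2 to compound 3 (0.11 log units; within the scatter) is therefore none beyond the scatter. Compound 3 is estimated at 700 nM, within 200 nM to 2500 nM.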

Compound 3, half-maximal inhibitory concentration: 45 nM
Beside the measured number, compound 3's estimate is 16-fold (1.19 log units) above it; the whole stated range lies above it.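

The aryl on the sulfonyl sulfur is a sensitive position: in this assay this exchange gives a 20-fold lower number from compound 2 to compound 3 (1.30 log units; beyond the scatter), whereas the earlier step concerned only the group on an oxygen on an aromatic ring. Isoquinolin-5-yl differs from 3-bromophenyl in several ways at once: it has a second ring, a ring nitrogen and a hydrogen-bond acceptor, and it has no bromine. Nothing measured here accounts for the size of this step. Which of these differences matters remains open. A naphthalen-1-yl on the sulfonyl sulfur would separate the second ring from the ring nitrogen.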